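The compounds below may be only part of what the source reports. "The series", "measured", "known", "first", "only" and "open" are said of these compounds alone.

Working notes on the series.

Compound 1 `NC(=O)/C=C/c1ccncc1-c1ccc2ccccc2c1` is the reference point. In a functional assay on KB cells (Homo sapiens) for inhibition, read by sulforhodamine B assay, with a stated time of 72 h (a lower number here means a stronger inhibitor of growth, a higher number a weaker inhibitor of growth), compound 1 returns only a limit of the assay, > 10000 nM, and not a number. Compound 2 `CNC(=O)/C=C/c1ccncc1-c1ccc2c(cnn2C)c1` in this assay likewise gives a limit, > 10000 nM. Compound 3 `O=C(O)/C=C/c1ccncc1-c1ccc2[nH]ccc2c1` in this assay is also reported as a limit, > 10000 nM. The position of compound 1 is therefore set by the limit of > 10000 nM in this assay, at which 3 of the 3 values shown sit: it stands at the limit together with the other two measured compounds, and no ordering among the three is possible.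

Compound 4 `CN(C)C(=O)/C=C/c1ccncc1-c1ccc2ccccc2c1` is not yet measured. It differs from compound 1 in one place: dimethylamino in place of amino on a carbonyl carbon. Going by the values given here, no step between measured compounds exists in this set, so the size of this change cannot be read from the data. With every measured value a limit, there is no ground for expecting a step beyond the scatter in either direction, and the expected result for compound 4 is again a limit.

For compound 4 in this assay the estimate is 15000 nM, with a range from 5000 nM to 50000 nM. This corresponds to an expected step that the limit leaves unreadable from compound 1 to compound 4, which is none beyond the scatter.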

Compound 4, concentration for 50% growth inhibition: 7760 nM
Compound 4: the middle estimate sits 1.9-fold (0.29 log units) above what was measured; the range from low to high includes it.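

Dimethylamino in place of amino on this carbonyl carbon gives, in this assay, an at least 1.2-fold lower number from compound 1 to compound 4 (0.11 log units; that floor lies within the scatter), and compound 4 is the only compound of the four that returns a number and not a limit. The position therefore accepts the larger dimethylamino group, which has no hydrogen-bond donor, and growth inhibition can still be read there. The true size of the step stays unknown, and the printed floor alone does not show a real change, because compound 1 sits at a limit and not at a number: the limit of > 10000 nM in this assay, at which 3 of the 4 values shown sit.

The compounds shown leave open whether diethylamino or a ring amine such as pyrrolidine on the same carbonyl carbon would give a lower or higher number than compound 4. They also leave open whether the dimethylamino group would have a similar effect on a different core.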